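Swapping the Five-Membered Ring on a Shared Core

A few compounds are considered here, and "the series" means these few. Any claim that something is new, unique, unknown or untested is made for them only; others in the source may bear on it.

Two close relatives of one core have been measured. Compound 1 `Cc1noc(C)c1-c1cnc(N)c(Oc2ccc(C(=O)Nc3ccc(Cl)cn3)cc2)n1` carries an ether linkage out to its amide, and in a functional assay on HepG2 cells (Homo sapiens) for inhibition, read by MTT assay, with a stated time of 72 h (a lower number here means a stronger inhibitor, a higher number a weaker inhibitor), compound 1 gives 35600 nM. Compound 2 `Cc1noc(C)c1-c1cnc(N)c(Sc2ccc(C(=O)Nc3ccc(Cl)cc3)cc2)n1` carries a thioether in that position instead, and in this assay compound 2 gives 45200 nM. The gap between these two numbers is within the usual scatter, so neither compound can be called stronger or weaker than the other; both sit at the weak end of what this kind of assay reports.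

Compound 3 `Cn1cc(-c2cnc(N)c(Sc3ccc(C(=O)Nc4ccc(Cl)cc4)cc3)n2)cn1` keeps everything of compound 2 except the small aromatic ring that hangs off the core: 1-methyl-1H-pyrazol-4-yl in place of 3,5-dimethyl-1,2-oxazol-4-yl on an aromatic carbon. Among the compounds with values here, no measured pair here shows what such a swap of one five-membered ring for another does, so there is no direct precedent to lean on. With both measured compounds already weak and the change small in size, the step from compound 2 to compound 3 in this assay is expected to be a 1.1-fold lower number from compound 2 to compound 3 (0.05 log units; within the scatter), nothing beyond the scatter in either direction. For compound 3 in this assay the expected value is therefore 40000 nM, with a plausible range from 12000 nM to 130000 nM.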

Compound 3, half-maximal inhibitory concentration: > 100000 nM
Compound 3: no number, only a limit; the forecaster's own chance of this, stated with the estimate: 25%; at least 2.5-fold (0.39 log units) between middle value and limit.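

This position on the shared core is not indifferent to what it carries. Putting 1-methyl-1H-pyrazol-4-yl in place of 3,5-dimethyl-1,2-oxazol-4-yl gives an at least 2.2-fold higher number from compound 2 to compound 3 (0.34 log units; beyond the scatter), so exchanging one five-membered aromatic ring for another, each with the same count of hetero atoms and hydrogen-bond acceptors, can still shift the read-out of an already weak compound. In this assay compound 3 gives > 100000 nM, which is a limit of the assay and not a number. The full size of the step stays unknown because the value of compound 3 is such a limit, so the step marks only the smallest size it could have: the limit of > 100000 nM in this assay, at which 1 of the 3 values shown sits.

The compounds shown leave open which part of the swap matters, whether the two methyl groups on the 1,2-oxazole, the ring atoms themselves or the methyl group on the pyrazole nitrogen. Also open, as far as these compounds go, is how a phenyl ring, an amine or a carboxylic acid would behave on this same aromatic carbon, and whether the pyrazole would give a similar step in a compound with the ether linkage.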